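The source may hold more compounds than are shown below. What is called first, only, known or untested is meant among the compounds shown, and "the series" means these compounds.

Two measured compounds share one core, a chalcone-type scaffold carrying a vanillin-derived ring. Compound 1 `COc1cc(/C=C/C(=O)c2cccc(N=[N+]=[N-])c2)ccc1O` carries an azido group on the ring next to the carbonyl; in a functional assay on RAW264.7 cells (Mus musculus) for inhibition, with a stated time of 4 days (on this read-out lower numbers stand for stronger inhibition and higher numbers for weaker inhibition), compound 1 gives 7110 nM. Compound 2 `COc1ccc(/C=C/C(=O)c2cccc(N=[N+]=[N-])c2)cc1O` swaps the positions of the methoxy and hydroxy groups on the other ring; in this assay compound 2 gives 1960 nM. Compound 1 therefore stands at the higher, weaker end of the two numbers, and the gap to compound 2 lies beyond the usual scatter.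

Compound 3 `COc1cc(/C=C/C(=O)c2cccc(-n3cc(C(C)(C)O)nn3)c2)ccc1O` is not yet measured. Compared with compound 1, the change is 4-(1-hydroxy-1-methylethyl)-1H-1,2,3-triazol-1-yl in place of azido on an aromatic carbon. Within the data shown here, no comparable step is available, so the direction of the change is uncertain. The step from compound 1 to compound 3 is expected to be modest, probably a small move toward stronger inhibition: a 1.6-fold lower number from compound 1 to compound 3 (0.20 log units; within the scatter). Compound 3 is expected to give 4500 nM, with a range from 1200 nM to 16000 nM.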

Compound 3, half-maximal inhibitory concentration: 19800 nM
Beside the measured number, compound 3's estimate is 4.4-fold (0.64 log units) below it, and the stated range ends below it.
By their numbers in this assay, from the lowest: compound 2; then compound 1; then compound 3.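

The earlier compounds shown here varied only the other ring, so they said nothing about changing the azido group at this place. In this assay, putting 4-(1-hydroxy-1-methylethyl)-1H-1,2,3-triazol-1-yl in place of azido gives a 2.8-fold higher number from compound 1 to compound 3 (0.44 log units; beyond the scatter), so inhibition weakens beyond the scatter but only by a modest step, even though the entering group is much larger and brings a five-membered aromatic ring and a hydrogen-bond donor. No measurement is available here that accounts for this shift.

On these data alone, this single change cannot separate the triazole ring from its 1-hydroxy-1-methylethyl substituent, so it remains open which part goes with the weaker number. Also open, as far as these compounds go, are how a triazole carrying an amine or a carboxylic acid in place of that substituent would compare, and whether the same swap on the core of compound 2 would give a similar step.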